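Adding a Second Fluoro: What the Numbers Suggest

A few compounds are considered here, and "the series" means these few. Any claim that something is new, unique, unknown or untested is made for them only; others in the source may bear on it.

Measured compounds:
compound 1, `Nc1scc(CN2CCN(c3cccnc3)CC2)c1C(=O)c1ccc(Cl)cc1`, with 0%
compound 2, `Nc1scc(CN2CCN(C3CCCC3)CC2)c1C(=O)c1ccc(Cl)cc1`, with 3%
compound 3, `Nc1scc(CN2CCN(c3cccc(F)c3)CC2)c1C(=O)c1ccc(Cl)cc1`, with 4%

All three were tested in an assay on CHO cells for displacement of a labelled ligand from adenosine receptor A3 (Homo sapiens), read by scintillation counting, with a stated time of 120 min, tested at 10 uM; a higher number here means more inhibition at the concentration tested (going by the name of the read-out), a lower number less inhibition. On these numbers compound 3 sits within the usual scatter of both others: the step of a number 4 percentage points higher from compound 1 to compound 3 (within the scatter) and the step of a number 1 percentage points higher from compound 2 to compound 3 (within the scatter) are each too small to count as a real difference, as is a number 3 percentage points higher from compound 1 to compound 2 (within the scatter). Swapping the whole group on the amine nitrogen in the ring, whether pyridin-3-yl, cyclopentyl or 3-fluorophenyl, has so far moved nothing beyond the scatter.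

Compound 4, `Nc1scc(CN2CCN(c3ccc(F)c(F)c3)CC2)c1C(=O)c1ccc(Cl)cc1`, differs from compound 3 by fluoro in place of hydrogen on an aromatic carbon. Among the measured compounds shown here, no measured step adds a fluoro to an aromatic carbon, so the closest guides are the three small steps above, all of them within the scatter. A step of similar size is therefore expected, with no clear direction: the expected step is no change at the digits printed from compound 3 to compound 4 (within the scatter). Compound 4 is estimated to give 4% in this assay, within the range -6% to 14%.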

Compound 4, a percentage reported as inhibition, at one concentration (the size of the read-out at that concentration, not a potency): 1%
Compound 4: middle estimate off by 3 percentage points, on the high side, and the stated range covers the measured number.
By their numbers in this assay, from the lowest: compounds 1, 4, 2 and 3 (each within the scatter of the next).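

The added fluoro, ortho to a fluoro group and para to a large group, gives a number 3 percentage points lower from compound 3 to compound 4 (within the scatter) in this assay, so this aromatic carbon accepts the change without any shift beyond the scatter. The 3,4-difluorophenyl group also stays level with the other groups on the amine nitrogen, as shown by a number 2 percentage points lower from compound 2 to compound 4 (within the scatter) and by a number 1 percentage points higher from compound 1 to compound 4 (within the scatter), so the four compounds still cannot be told apart. No supporting measurement is available to explain this result.

Open, as far as these compounds go, is whether any change at this position or on the amine nitrogen can produce a reading clearly beyond the scatter. A methoxy group or a nitrile on the same aromatic carbon, or a longer chain on the amine nitrogen, would be a further test of that.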